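The compounds below may be only part of what the source reports. "The series", "measured", "known", "first", "only" and "open" are said of these compounds alone.

Of the compounds shown here, three have numbers so far in an ADME assay on MT4 cells (Homo sapiens) for cytotoxicity, read by MTT assay, with a stated time of 4 days (a lower number here means that less compound is tolerated, a higher number that more compound is tolerated), and compound 2 (`COc1cccc(-c2oc3ccc(N)cc3c(=O)c2O)c1`) stands second highest of them at 40800 nM in that assay. Compound 1 (`COc1cccc(-c2cc(=O)c3cc(N)ccc3o2)c1`) lies higher at 247000 nM on the same scale. Compound 3 (`Nc1ccc2oc(-c3cccc(C(F)(F)F)c3)c(O)c(=O)c2c1`) lies lower at 8100 nM and is the lowest of the three.

Compound 4 (`COc1cccc(-c2oc3ccc(N)cc3c(=O)c2OC)c1`) departs from compound 2 by a single change, methyl in place of hydrogen on an oxygen on an aromatic ring, which reads as hydroxy to methoxy.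

Among the compounds with values here, two measured steps bear on this, neither directly. The closer one is hydroxy in place of hydrogen on an aromatic carbon (a 6.1-fold lower number from compound 1 to compound 2 (0.78 log units; beyond the scatter)), a modest step that concerns the same hydroxy now being capped. Compound 4 keeps an oxygen there but loses the hydroxy hydrogen, so part of that step may be given back. The other step, trifluoromethyl in place of methoxy (a 5.0-fold lower number from compound 2 to compound 3 (0.70 log units; beyond the scatter)), was also modest but changes a different place and says little here. Within the data shown here, no measured compound carries a methoxy at this place, so the direction remains tentative.

A small rise is expected, with the estimated step being a 2.2-fold higher number from compound 2 to compound 4 (0.34 log units; beyond the scatter) in this assay for this change. Compound 4 is expected at 90000 nM (estimated range 30000 nM to 250000 nM).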

Compound 4, half-maximal cytotoxic concentration: 251000 nM
Compound 4: middle estimate off by 2.8-fold (0.45 log units), on the low side; the whole stated range lies below it.
By their numbers in this assay, from the lowest: compound 3; then compound 2; then compounds 1 and 4 (each within the scatter of the next).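

In this assay the capping of the hydroxy as methoxy gives a 6.2-fold higher number from compound 2 to compound 4 (0.79 log units; beyond the scatter) and so runs opposite to the step that brought the hydroxy in, which was a 6.1-fold lower number from compound 1 to compound 2 (0.78 log units; beyond the scatter) on the same scale. Methoxy in place of hydrogen on the aromatic carbon gives a 1.0-fold higher number from compound 1 to compound 4 (0.01 log units; within the scatter) and leaves compound 1 and compound 4 indistinguishable, so the lower number in this series goes with the free hydroxy and not with the mere presence of an oxygen at this place. This holds for compound 1, compound 2 and compound 4 only, and nothing shown accounts for the link between the hydroxy hydrogen and the number in this assay.

Going by these compounds, it remains open whether ethoxy, an acetyl ester or an amine at this place would read like the hydroxy or like the methoxy. It also remains open whether the same capping would raise the number when trifluoromethyl replaces the methoxy on the aromatic ring, since compound 3 has no capped partner among these compounds.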